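This account rests on a few compounds, and the source may have more. Where it says the series, first, only, none or still open, it means among the compounds named here.

Measured so far in an ADME assay on BHK-21 cells (Mesocricetus auratus) for cytotoxicity, read by MTT assay, with a stated time of 96 h; a lower number here means that less compound is tolerated, a higher number that more compound is tolerated (half-maximal cytotoxic concentration):
compound 1 `Cc1ccc(/N=N/N(C)c2ccccc2)cc1` gives > 100000 nM (a limit)
compound 2 `Fc1ccc(F)c(/N=N/c2ccc(NC[C@@H]3CCCN4CCCC[C@H]34)c3c2CCCC3)c1` gives 38000 nM (a number)

Compound 1 gives > 100000 nM as a limit of the assay and not a number, so its place in the series is known only as a limit. Within the data shown here, the series so far shows the limit of > 100000 nM in this assay, at which 1 of the 2 values shown sits, and nothing more on this point.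

The unmeasured compound 3 `CN(/N=N/c1ccccc1)c1ccccc1` comes from compound 1 by a single change: hydrogen in place of methyl on an aromatic carbon. Among the measured compounds shown here, no measured pair isolates a change of this kind, so the expectation rests on the structural change alone. In this assay no step beyond the usual scatter is expected. Any shift that does appear is expected toward a lower number, since compound 1 stands at > 100000 nM as a limit. The estimated at least 1.1-fold lower number from compound 1 to compound 3 (0.07 log units; that floor lies within the scatter) is expected to be small. The estimate for compound 3 is 85000 nM as a middle value, with an expected range from 35000 nM to 100000 nM in this series.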

Compound 3, half-maximal cytotoxic concentration: > 100000 nM
Compound 3: only a limit was reported; the forecaster's own chance of this, stated with the estimate: 55%; middle value at least 1.1-fold (0.07 log units) from the limit.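

In this assay compound 3 gives > 100000 nM, which is a limit and not a number. Compound 1 gives > 100000 nM, also a limit. No step between compound 1 and compound 3 can be read from these two limits: the limit of > 100000 nM in this assay, at which 2 of the 3 values shown sit.

The compounds shown leave open whether hydrogen in place of methyl on an aromatic carbon shifts this read-out at all.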